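This account rests on a few compounds, and the source may have more. Where it says the series, first, only, none or still open, it means among the compounds named here.

Measured so far:
compound 1, `Oc1ccc(-c2cc(-c3cccc(F)c3)cc(-c3cccc(O)c3)n2)cc1`: 14200 nM
compound 2, `Oc1ccc(-c2cc(-c3ccccc3F)cc(-c3ccc(O)cc3)n2)cc1`: > 50000 nM

Both values come from a functional assay on HeLa cells (Homo sapiens) for inhibition; on this read-out higher numbers stand for weaker inhibition and lower numbers for stronger inhibition. Compound 1 gives 14200 nM there. Compound 2 gives no number in this assay; it reaches only the limit of > 50000 nM. On these data alone, that value is the limit of > 50000 nM in this assay, at which 1 of the 2 values shown sits, so where compound 2 truly stands is unknown beyond that bound.

The next compound, compound 3, `Oc1ccc(-c2cc(-c3cccc(F)c3)cc(-c3ccc(O)cc3)n2)cc1`, has not yet been measured. It differs from compound 2 in one place: 3-fluorophenyl in place of 2-fluorophenyl on an aromatic carbon. Compound 3 thus carries the 3-fluorophenyl group that compound 1 also carries, while its two 4-hydroxyphenyl groups match those of compound 2.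

Among the measured compounds shown here, no step between measured compounds is available, so nothing fixes the size of the change from a 2-fluorophenyl to a 3-fluorophenyl group in this assay. For the measured compounds named here, compound 1, the only measured compound with a 3-fluorophenyl group, gives 14200 nM. On that basis compound 3 is expected to give a measurable value of about 25000 nM, in the range 8000 nM to 80000 nM. The step this estimate implies, an at least 2.0-fold lower number from compound 2 to compound 3 (0.30 log units; that floor lies within the scatter), is expected to lead towards stronger inhibition, though with a fair chance that compound 3 again reaches only the limit.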

Compound 3, half-maximal inhibitory concentration: > 50000 nM
Compound 3 gave a limit, no number; the forecaster's own chance of this, stated with the estimate: 35%; middle value at least 2.0-fold (0.30 log units) from the limit.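

In this assay the change from 2-fluorophenyl to 3-fluorophenyl on this aromatic carbon cannot be sized, because compound 2 and compound 3 both end at a limit and not at a number: the limit of > 50000 nM in this assay, at which 2 of the 3 values shown sit. The readable information comes from the other position: with the 3-fluorophenyl group held constant, 4-hydroxyphenyl in place of 3-hydroxyphenyl gives an at least 3.5-fold higher number from compound 1 to compound 3 (0.54 log units; beyond the scatter), which means weaker inhibition. The 3-fluorophenyl group alone therefore does not secure a measurable value in this assay; among these three compounds, only the one that also carries a 3-hydroxyphenyl group gives a number.

On these data alone, it remains open how far compound 2 and compound 3 truly lie beyond their limit, and whether moving the fluorine would have any visible effect on a compound that, like compound 1, carries a 3-hydroxyphenyl group. Also open, as far as these compounds go, is whether a methoxy group in place of the hydroxyl, or an amine or a carboxylic acid in place of the fluorine, would give stronger or weaker inhibition on the shared core.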